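Aryl group exchange on the shared core, binding readout

The compounds below may be only part of what the source reports. "The series", "measured", "known", "first", "only" and "open" are said of these compounds alone.

Measured so far:
Compound 1 `CCCS(=O)(=O)Nc1ccc(F)c(C(=O)c2n[nH]c3ncc(-c4cccc(F)c4)cc23)c1F` — compound 1 gives 8.2%
Compound 2 `CCCS(=O)(=O)Nc1ccc(F)c(C(=O)c2n[nH]c3ncc(-c4ccc(C(C)C)cc4)cc23)c1F` — compound 2 gives 17%
Not yet measured: compound 3 `CCCS(=O)(=O)Nc1ccc(F)c(C(=O)c2n[nH]c3ncc(-c4ccc(F)cc4C)cc23)c1F`

In an assay for binding affinity to dual specificity mitogen-activated protein kinase kinase 4 (Homo sapiens), read by KINOMEscan, tested at 100 nM (a lower number here means a stronger effect, a higher number a weaker effect of the compound at the concentration tested), compound 1 gives 8.2% and compound 2 gives 17%. Compound 2 holds the higher of the two numbers, but a number 8.8 percentage points higher from compound 1 to compound 2 (within the scatter) is within the scatter, so no order between them is claimed. Compound 3 carries 4-fluoro-2-methylphenyl in place of 4-isopropylphenyl on an aromatic carbon. For the measured compounds named here, the one step that bears on this change is a number 8.8 percentage points higher from compound 1 to compound 2 (within the scatter), likewise an exchange of the aryl group on an aromatic carbon, which left the read-out within the scatter. The expected step is therefore a number 4 percentage points lower from compound 2 to compound 3 (within the scatter), nothing beyond the scatter. Compound 3 is estimated at 13%, with a range from 4% to 30%.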

Compound 3, a percentage reported as activity, at one concentration (the size of the read-out at that concentration, not a potency): 14%
Compound 3: middle estimate off by 1 percentage points, on the low side; measured number inside the range.
By their numbers in this assay, from the lowest: compounds 1, 3 and 2 (each within the scatter of the next).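

In this assay, 4-fluoro-2-methylphenyl in place of the earlier aryl groups gives a number 3 percentage points lower from compound 2 to compound 3 (within the scatter) and a number 5.8 percentage points higher from compound 1 to compound 3 (within the scatter). The exchange on this aromatic carbon now spans three substituted phenyl groups, and compounds 1, 2 and 3 fall in no order. Nothing available explains this outcome.

Still open, as far as these compounds go, is whether any group at this position moves the read-out beyond the scatter, for example a pyridine ring in place of the phenyl, or a phenyl carrying a carboxylic acid or an amine.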